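The source may hold more compounds than are shown below. What is called first, only, known or untested is meant among the compounds shown, and "the series" means these compounds.

Measured in an assay on isolated protein for inhibition of serine protease 1 (Homo sapiens), read by fluorescence; a higher number here means a weaker inhibitor, a lower number a stronger inhibitor:

Compound 1, `CNC(=O)[C@@H]1C[C@H](n2cc(C3CC3)nn2)CN1C(=O)c1ccc(CN)c(OC)c1`: 2100 nM
Compound 2, `COc1cc(C(=O)N2C[C@@H](n3cc(C4CC4)nn3)C[C@H]2C(=O)N[C@H]2CCCC[C@@H]2c2ccccc2)ccc1CN`: 19 nM

Compound 2 has the lowest number of the two in this assay, and its nearest neighbour is compound 1, which stands far higher. Going by the values given here, the single step between them, a 110-fold lower number from compound 1 to compound 2 (2.04 log units; beyond the scatter), shows how much the amide substituent matters here. Compound 3, `COc1cc(C(=O)N2C[C@@H](n3cc(C4CC4)nn3)C[C@H]2C(=O)N[C@@H]2C[C@H]2c2ccccc2)ccc1CN`, differs from compound 2 in one place: 2-phenylcyclopropyl in place of 2-phenylcyclohexyl on an amide-type nitrogen. The phenyl group that entered in the large step from compound 1 to compound 2 is kept, but the six-membered ring that carries it shrinks to a three-membered one. Among the compounds with values here, no measured step tests this change directly; only the step from compound 1 to compound 2 bears on it, and it suggests the phenyl-bearing group is important while the ring size is untested. A moderate rise in number is therefore expected, a 4.2-fold higher number from compound 2 to compound 3 (0.62 log units; beyond the scatter), with compound 3 estimated at 80 nM, within a range of 20 nM to 400 nM.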

Compound 3, half-maximal inhibitory concentration: 110 nM
The estimate for compound 3 lay 1.4-fold (0.14 log units) below the measured number, and the stated range covers the measured number.
By their numbers in this assay, from the lowest: compound 2; then compound 3; then compound 1.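

In this assay, the ring carrying the phenyl on this amide-type nitrogen turns out to matter in its own right: replacing 2-phenylcyclohexyl with 2-phenylcyclopropyl gives a 5.8-fold higher number from compound 2 to compound 3 (0.76 log units; beyond the scatter) as a modest change. Even so, a 19-fold lower number from compound 1 to compound 3 (1.28 log units; beyond the scatter) is still a large step when 2-phenylcyclopropyl replaces methyl, so the gain over methyl does not depend on having the six-membered ring. No supporting evidence is available to explain why changing the ring shifts the number.

The compounds shown do not separate the contribution of the phenyl from that of the ring carrying it, as a plain cyclohexyl group would. As far as these compounds go, a 2-phenylcyclopentyl group, with a ring size between the two tested, and a simple benzyl group also remain open.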